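Inverting One Ring Stereocentre: Compound 3 to Compound 4

A few compounds are considered here, and "the series" means these few. Any claim that something is new, unique, unknown or untested is made for them only; others in the source may bear on it.

Of the compounds shown here, three have been measured in a functional assay on L1210 cells (Mus musculus) for cytotoxicity; a higher number here means a weaker inhibitor, a lower number a stronger inhibitor. Compound 1 `CC(CCCC/C=C/CC/C=C\c1ccccc1)C[C@]1(C)C[C@@](C)(CC(=O)O)OO1` gives 0.017 ug/mL, compound 2 `CC(CC/C=C/CC/C=C/c1ccccc1)C[C@]1(C)C[C@@](C)(CC(=O)O)OO1` gives 0.026 ug/mL, and compound 3 `COC(=O)C[C@]1(C)C[C@@](C)(CC(C)CCCC/C=C/CC/C=C\c2ccccc2)OO1` gives 0.013 ug/mL. Compound 3 carries the lowest of the three numbers, yet its gaps to compound 1 and to compound 2 both lie within the scatter, so the three cannot be ranked against one another. Within the data shown here, the only single-change comparison among them, a 1.3-fold lower number from compound 1 to compound 3 (0.12 log units; within the scatter), also stayed within the scatter.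

Compound 4 `COC(=O)C[C@@]1(C)C[C@@](C)(CC(C)CCCC/C=C/CC/C=C\c2ccccc2)OO1` differs from compound 3 in one point: the two compounds have the same atoms and bonds; at least one stereo element is drawn with a configuration in one of them and without one in the other: 1 of 5 stereo elements differ; a stereocentre at a saturated ring carbon is drawn S in compound 3 and R in compound 4. Among the measured compounds shown here, none of the measured steps involves a change of configuration, so none of them bears directly on this step. With no comparison of this kind available, the expected step is set close to no change, with a wide range to allow for movement in either direction. Compound 4 is therefore expected to give an estimated 0.03 ug/mL, within 0.008 ug/mL to 0.15 ug/mL. That estimate amounts to an expected step of a 2.3-fold higher number from compound 3 to compound 4 (0.36 log units; beyond the scatter).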

Compound 4, half-maximal inhibitory concentration: 0.29 ug/mL
Compound 4: the middle estimate sits 9.7-fold (0.99 log units) below what was measured, and the stated range ends below it.
By their numbers in this assay, from the lowest: compounds 3, 1 and 2 (each within the scatter of the next); then compound 4.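

In this assay, inverting a single stereocentre at a saturated ring carbon gives a 22-fold higher number from compound 3 to compound 4 (1.35 log units; beyond the scatter), so the spatial arrangement at this one position matters, even with every atom and bond unchanged. The earlier single-change step, a 1.3-fold lower number from compound 1 to compound 3 (0.12 log units; within the scatter), swapped hydrogen for methyl at the carboxylic acid oxygen and stayed within the scatter, so this is the first change shown to move the number clearly. The structural record offers only one fact about the pair: the fact that one of compounds 3 and 4 is drawn with a defined configuration and the other without, at the place where they differ

From the compounds shown here alone, whether the same inversion has a similar effect on the free carboxylic acid of compound 1 stays open, as does the effect of inverting the other stereo elements. It is also unknown whether a compound with an amide in place of the ester, or with a longer chain, would show the same sensitivity.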